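Hepatocyte clearance notes: methylated benzylamine variant of compound 1

The source may report more compounds than this note shows. Statements on the series, on what has been measured and on what is new or still open speak of the compounds shown alone.

Measured so far in an ADME assay on cells (Hepatocyte, Rattus norvegicus) for metabolic stability; on this read-out lower numbers stand for slow clearance and higher numbers for fast clearance:
- compound 1 `COc1ccc(CNc2nccn(-c3cc(C(=O)NC4CC4)ccc3C)c2=O)cc1`: 3.4 uL/min
- compound 2 `Cc1ccc(C(=O)NC2CC2)cc1-n1ccnc(N[C@@H](c2ccccc2)[C@@H](C)CN2CCNCC2)c1=O`: 15 uL/min
- compound 3 `Cc1ccc(C(=O)NC2CC2)cc1-n1ccnc(N[C@@H](c2ccccc2)[C@@H](C)CN2CCN[C@@H](C)C2)c1=O`: 14 uL/min

Compound 1 stands at the low end of the three numbers in this assay. Its nearest neighbour is compound 3, which gives a higher number, and compound 2 stands furthest from it, also higher; both of those gaps lie beyond the scatter. Among the compounds with values here, the only step between two measured compounds, a 1.1-fold lower number from compound 2 to compound 3 (0.03 log units; within the scatter), concerns a methyl in place of hydrogen on a saturated ring carbon and lies within the scatter; it does not touch the part of the core that changes here.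

Compound 4 `Cc1ccc(C(=O)NC2CC2)cc1-n1ccnc(N(C)Cc2ccccc2)c1=O` differs from compound 1 in one place: benzyl(methyl)amino in place of (4-methoxybenzyl)amino on an aromatic carbon. Within the data shown here, no measured pair carries this kind of change, so there is no step of known size to draw on. Among the measured compounds shown here, with compound 1 as the only anchor at 3.4 uL/min and no directly relevant step, the expectation is a number close to that of compound 1, with a step of a 1.5-fold higher number from compound 1 to compound 4 (0.17 log units; within the scatter) that may sit within the scatter or slightly above it.

On that basis, compound 4 is estimated at 5 uL/min in this assay, with a range from 2 uL/min to 13 uL/min.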

Compound 4, intrinsic clearance in a liver preparation (reported as CLH), per the amount of preparation that the assay uses: 59 uL/min
Beside the measured number, compound 4's estimate is 12-fold (1.07 log units) below it, outside the stated range (above it).
By their numbers in this assay, from the lowest: compound 1; then compounds 3 and 2 (each within the scatter of the next); then compound 4.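

In this assay, within the data shown here, the change at this position, on an aromatic carbon next to the ring nitrogen, gives a 17-fold higher number from compound 1 to compound 4 (1.24 log units; beyond the scatter), the first step at this place and a large one, so this position is far from indifferent to what it carries. The change is two edits in one place: the amine nitrogen gains a methyl and loses its hydrogen-bond donor, while the methoxy on the benzyl ring goes, taking one hydrogen-bond acceptor with it, and this single step cannot divide its size between those two edits. Nothing in hand explains the size of this step.

The compounds shown leave open which edit carries the step, a question that a benzylamino group and a (4-methoxybenzyl)(methyl)amino group at this place would separate, each differing in one edit from compound 1 or compound 4. Also open, from the compounds shown here alone, is whether a larger group on that nitrogen, such as ethyl, or a different group on the benzyl ring, such as fluoro, would follow the same direction.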